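The compounds below may be only part of what the source reports. "The series", "measured", "known", "first", "only" and "open" are said of these compounds alone.

Measured compounds:
compound 1 `O=C(/C=C/c1cccc(O)c1)c1cccc(-n2cc(-c3ccc(Cl)cc3)[nH]c2=O)c1`
compound 2 `COc1cc(/C=C/C(=O)c2cccc(-n3cc(-c4ccccc4)[nH]c3=O)c2)cc(OC)c1OC`

In a functional assay on Malme-3M cells (Homo sapiens) for inhibition (on this read-out higher numbers stand for weaker inhibition of growth and lower numbers for stronger inhibition of growth), compound 2 gives 1310 nM, the lower of the two numbers. The nearest is compound 1, which in this assay gives 1830 nM; the gap between the two lies within the scatter, so no order between them is claimed.

Compound 3 `COc1cc(/C=C/C(=O)c2cccc(-n3cc(-c4cc(OC)c(OC)c(OC)c4)[nH]c3=O)c2)cc(OC)c1OC` differs from compound 2 in one place: 3,4,5-trimethoxyphenyl in place of phenyl on an aromatic carbon. Among the measured compounds shown here, no measured pair shows this change, so nothing about its size is known from the numbers. The step of a 1.3-fold lower number from compound 2 to compound 3 (0.12 log units; within the scatter) is expected to be small, not clearly beyond the scatter, with the direction open. Compound 3 is estimated at 1000 nM, with a range from 300 nM to 3500 nM.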

Compound 3, concentration for 50% growth inhibition: 1800 nM
Beside the measured number, compound 3's estimate is 1.8-fold (0.26 log units) below it, within the range that was stated.
By their numbers in this assay, from the lowest: compounds 2, 3 and 1 (each within the scatter of the next).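

In this assay the swap on this aromatic carbon next to the ring nitrogen gives a 1.4-fold higher number from compound 2 to compound 3 (0.14 log units; within the scatter) and so stays within the scatter. The carbon therefore carries 3,4,5-trimethoxyphenyl, with 12 heavy atoms against 6 for phenyl, without a step beyond the scatter in this read-out. No measurement bears on why this step is as it is. On these data alone, whether an amine or a carboxylic acid on the same carbon would also stay within the scatter remains open. So does whether a single methoxy on the phenyl would.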